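The compounds below may be only part of what the source reports. "The series", "measured", "known", "first", "only" and "open" are said of these compounds alone.

Values in a functional assay on MDA-MB-231 cells (Homo sapiens) for antiproliferative activity, with a stated time of 48 h (on this read-out lower numbers stand for stronger inhibition and higher numbers for weaker inhibition), follow
Compound 1 `CCN(CC)c1ccc(-c2cccc(C#N)c2)nn1` gives > 25000 nM as a limit of the assay
Compound 2 `CCN(CC)c1ccc(-c2ccc(C(C)=O)cc2)nn1` gives 5000 nM
Compound 3 `CCN(CC)c1ccc(-c2ccc(C(=O)OC)cc2)nn1` gives 140 nM

Compound 3 at 140 nM holds the lower of the two actual numbers, well clear of compound 2. Compound 4 `CCOC(=O)c1ccc(-c2ccc(N(CC)CC)nn2)cc1` carries ethoxycarbonyl where compound 3 carries methoxycarbonyl, and the difference is methyl in place of hydrogen on a saturated chain carbon bound to an oxygen next to a carbonyl group on that ester chain. For the measured compounds named here, the only measured step bearing on this is a 36-fold lower number from compound 2 to compound 3 (1.55 log units; beyond the scatter) with methoxy in place of methyl on a carbonyl carbon. That large step replaced the group on the carbonyl carbon, whereas methoxy to ethoxy keeps it as an alkoxy group, so a far smaller change is expected in this assay, if anything towards a slightly higher number. The expected step is a 1.6-fold higher number from compound 3 to compound 4 (0.20 log units; within the scatter) in size. Compound 4 is estimated at 220 nM with a range of 70 nM to 800 nM as the expected span.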

Compound 4, half-maximal inhibitory concentration: 1500 nM
Compound 4: the middle estimate sits 6.8-fold (0.83 log units) below what was measured, outside the stated range (above it).
By their numbers in this assay, from the lowest: compound 3; then compound 4; then compound 2. At a limit, above all of these: compound 1.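

In this assay, methoxy and ethoxy on the ester are not interchangeable: methyl in place of hydrogen on a saturated chain carbon bound to an oxygen next to a carbonyl group gives an 11-fold higher number from compound 3 to compound 4 (1.03 log units; beyond the scatter) as a large step. The ethoxy ester gives only a 3.3-fold lower number from compound 2 to compound 4 (0.52 log units; beyond the scatter) as a modest step, against the large 36-fold lower number from compound 2 to compound 3 (1.55 log units; beyond the scatter) for methoxy. Nothing measured here accounts for this loss. As far as these compounds go, whether a longer chain or a carboxylic acid at this place continues the trend stays open.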